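A few compounds are considered here, and "the series" means these few. Any claim that something is new, unique, unknown or untested is made for them only; others in the source may bear on it.

Series on the shared core of compound 1 `CCCCCCCCn1cc(CO[C@H]2CC(=O)[C@@H]3OC[C@H]2O3)nn1`, varied only in the group carried on an aromatic nitrogen. In a functional assay on MDA-MB-231 cells (Homo sapiens) for cytotoxicity, read by MTT assay, with a stated time of 48 h (a higher number here means a weaker inhibitor, a lower number a stronger inhibitor), compound 1 gives only a limit of the assay, > 50000 nM. Compound 2 `O=C1C[C@H](OCc2cn(-c3ccc(Cl)cc3)nn2)[C@H]2CO[C@@H]1O2` gives 26100 nM in this assay, and compound 3 `O=C1CCCCC1n1cc(CO[C@H]2CC(=O)[C@@H]3OC[C@H]2O3)nn1` gives 36000 nM. Of the two numbers, compound 3 stands at the highest, though only by a 1.4-fold higher number from compound 2 to compound 3 (0.14 log units; within the scatter). Against the limit there is an at least 1.3-fold lower number from compound 1 to compound 3 (0.14 log units; that floor lies within the scatter) and an at least 1.9-fold lower number from compound 1 to compound 2 (0.28 log units; that floor lies within the scatter); the limit of > 50000 nM in this assay, at which 1 of the 3 values shown sits, means both of those steps are floors rather than sizes.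

Compound 4 `O=C1C[C@H](OCc2cn(C3CCCCC3)nn2)[C@H]2CO[C@@H]1O2` differs from compound 3 by cyclohexyl in place of 2-oxocyclohexyl on an aromatic nitrogen. Among the compounds with values here, the steps that bear on it are the other exchanges of the group on that aromatic nitrogen, and none of them resolves beyond the scatter; no measured step goes from 2-oxocyclohexyl to cyclohexyl. The expected step of a 1.1-fold higher number from compound 3 to compound 4 (0.05 log units; within the scatter) in this assay is therefore none beyond the scatter. Compound 4 is estimated at 40000 nM in this assay, with a range of 15000 nM to 100000 nM.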

Compound 4, half-maximal inhibitory concentration: 24300 nM
The estimate for compound 4 lay 1.6-fold (0.22 log units) above the measured number, and the stated range covers the measured number.
By their numbers in this assay, from the lowest: compounds 4, 2 and 3 (each within the scatter of the next). At a limit, above all of these: compound 1.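

In this assay, cyclohexyl in place of 2-oxocyclohexyl on the aromatic nitrogen takes away the group's only hydrogen-bond acceptor, and the result is a 1.5-fold lower number from compound 3 to compound 4 (0.17 log units; within the scatter); at this position, that exchange does not resolve. Cyclohexyl in place of 4-chlorophenyl gives a 1.1-fold lower number from compound 2 to compound 4 (0.03 log units; within the scatter), so these two ring groups cannot be told apart here either. Cyclohexyl in place of octyl gives an at least 2.0-fold lower number from compound 1 to compound 4 (0.31 log units; beyond the scatter), the first step in the series to clear the scatter, but its true size stays unknown because compound 1 is recorded only as a limit: the limit of > 50000 nM in this assay, at which 1 of the 4 values shown sits.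

Going by these compounds, it remains open whether an amine or a carboxylic acid on the cyclohexyl ring would shift the number beyond the scatter. A butyl chain in place of octyl would show whether chain length matters at this position.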